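The compounds below may be only part of what the source reports. "The series", "measured", "known", "first", "only" and "open" are said of these compounds alone.

Compound 1 `COc1ccc(C(=O)ON=C2CC(c3ccc(O)c(OC)c3)N(C)C(c3ccc(O)c(OC)c3)C2)cc1`: 40000 nM
Compound 2 `COc1cc(C2CC(=NOC(=O)c3ccccc3O)CC(c3ccc(O)c(OC)c3)N2C)ccc1O`: 24100 nM
Compound 3 `COc1cc(C2CC(=NOC(=O)c3ccc(O)cc3)CC(c3ccc(O)c(OC)c3)N2C)ccc1O`: 22500 nM

All three were measured in a functional assay on microsomes from liver (Rattus norvegicus, strain Wistar) for inhibition, read by spectrophotometry, with a stated time of 60 min (a higher number here means a weaker inhibitor, a lower number a stronger inhibitor), and all three are weak inhibitors. Compound 3 has the lowest of the three numbers, but both a 1.8-fold lower number from compound 1 to compound 3 (0.25 log units; within the scatter) and a 1.1-fold lower number from compound 2 to compound 3 (0.03 log units; within the scatter) stay within the scatter, so none of the three can be set apart from the others.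

Compound 4 `COc1cc(C2CC(=NOC(=O)c3ccc(Br)cc3)CC(c3ccc(O)c(OC)c3)N2C)ccc1O` differs from compound 3 by bromo in place of hydroxy on an aromatic carbon. The two steps that changed the same ring, a 1.8-fold lower number from compound 1 to compound 3 (0.25 log units; within the scatter) and a 1.1-fold lower number from compound 2 to compound 3 (0.03 log units; within the scatter), were both within the scatter, so another change of the group on that ring is expected to leave the number essentially where it is. Compound 4 is therefore expected to give about 25000 nM, within a range of 10000 nM to 60000 nM, which means an expected step of a 1.1-fold higher number from compound 3 to compound 4 (0.05 log units; within the scatter).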

Compound 4, half-maximal inhibitory concentration: 112000 nM
Compound 4: the middle estimate sits 4.5-fold (0.65 log units) below what was measured, and the stated range ends below it.
By their numbers in this assay, from the lowest: compounds 3, 2 and 1 (each within the scatter of the next); then compound 4.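

In this assay, going by these compounds alone, the group on this ring turns out to matter: bromo in place of hydroxy at the same place gives a 5.0-fold higher number from compound 3 to compound 4 (0.70 log units; beyond the scatter), the first step beyond the scatter, and it goes towards weaker inhibition. Bromo also stands apart from the other two ring patterns, with a 4.6-fold higher number from compound 2 to compound 4 (0.67 log units; beyond the scatter) and a 2.8-fold higher number from compound 1 to compound 4 (0.45 log units; beyond the scatter).

Nothing available here bears on why this change weakens inhibition. On these data alone, whether chloro or an amine at this place would track with bromo or with hydroxy stays open.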